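From cyclopropyl to 2-(piperidin-1-yl)ethyl on an amide-type nitrogen

The compounds below may be only part of what the source reports. "The series", "measured", "known", "first", "only" and "open" are said of these compounds alone.

Compound 3 (`COc1ncc(-c2ccc3nc(NC(=O)NC4CC4)nn3c2)cc1NS(=O)(=O)c1ccc(F)cc1`) gives 540 nM in a functional assay on U-87MG ATCC cells for cytotoxicity against U-87 MG (Homo sapiens), read by MTT assay, with a stated time of 72 h; a higher number here means a weaker inhibitor, a lower number a stronger inhibitor. Compound 1 (`COc1ncc(-c2ccc3nc(NC(=O)NCC(=O)N4CCCCC4)nn3c2)cc1NS(=O)(=O)c1ccc(F)cc1`) gives 740 nM and compound 2 (`COc1ncc(-c2ccc3nc(NC(=O)N(C)C)nn3c2)cc1NS(=O)(=O)c1ccc(F)cc1`) gives 1780 nM there, so compound 3 sits level with compound 1 and apart from compound 2. The next compound, compound 4 (`COc1ncc(-c2ccc3nc(NC(=O)NCCN4CCCCC4)nn3c2)cc1NS(=O)(=O)c1ccc(F)cc1`), carries 2-(piperidin-1-yl)ethyl in place of cyclopropyl on an amide-type nitrogen. The closest guide is compound 1, which also holds a piperidine-bearing group on that nitrogen, and its step to compound 3 stayed small (a 1.4-fold lower number from compound 1 to compound 3 (0.14 log units; within the scatter)). The steps involving compound 2 are larger (a 2.4-fold higher number from compound 1 to compound 2 (0.38 log units; beyond the scatter)) and (a 3.3-fold lower number from compound 2 to compound 3 (0.52 log units; beyond the scatter)), but its dimethylamino group resembles the new chain less. For the measured compounds named here, no measured compound carries 2-(piperidin-1-yl)ethyl itself, so the uncertainty stays wide. The expected step (a 1.1-fold higher number from compound 3 to compound 4 (0.06 log units; within the scatter)) is therefore none beyond the scatter, in either direction. Compound 4 is estimated at 620 nM (range 220 nM to 1800 nM) when it is measured.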

Compound 4, half-maximal inhibitory concentration: 1080 nM
The estimate for compound 4 lay 1.7-fold (0.24 log units) below the measured number, within the range that was stated.
By their numbers in this assay, from the lowest: compounds 3, 1, 4 and 2 (each within the scatter of the next, the first and the last beyond it).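

In this assay, 2-(piperidin-1-yl)ethyl in place of cyclopropyl gives a 2.0-fold higher number from compound 3 to compound 4 (0.30 log units; within the scatter) and (2-(piperidin-1-yl)ethyl)amino in place of dimethylamino gives a 1.6-fold lower number from compound 2 to compound 4 (0.22 log units; within the scatter), so compound 4 lies within the scatter of both, although those two neighbours lie beyond it from each other. (piperidin-1-yl)methyl in place of (piperidin-1-yl)carbonyl gives a 1.5-fold higher number from compound 1 to compound 4 (0.16 log units; within the scatter), so at this position the carbonyl in the chain of compound 1 makes no difference beyond the scatter. Nothing available here explains these steps. On these data alone, it remains open whether a morpholine ring in place of the piperidine ring, or a longer chain ending in the same piperidine ring, would give a step beyond the scatter. As far as these compounds go, how these amide-type nitrogen groups behave in other cell lines also remains open.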